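The compounds below may be only part of what the source reports. "The series", "measured", "known", "first", "only" and "open" are said of these compounds alone.

Compound 1 `N#Cc1cc(NC(=O)CN2C(=O)/C(=C/c3ccc(-c4ccc(Cl)cc4)o3)SC2=S)ccc1C(F)(F)F`: in a functional assay on K562 cells (Homo sapiens) for cytotoxicity, read by MTT assay, with a stated time of 72 h (a higher number here means a weaker inhibitor, a lower number a stronger inhibitor), compound 1 gives only a limit, > 250000 nM.
Compound 2 `O=C(CN1C(=O)/C(=C/c2ccc(-c3ccc(Cl)cc3)o2)SC1=S)NCc1ccc(Br)cc1`: in this assay compound 2 gives 68000 nM.
Compound 3 `O=C(CN1C(=O)/C(=C/c2ccc(-c3ccc(Cl)cc3)o2)SC1=S)Nc1nnn[nH]1`: in this assay compound 3 gives 52000 nM.

Compound 3 holds the lower of the two numbers available; compound 2 sits nearest, within the scatter of it. Compound 1 gives no number, since its value is the limit (the limit of > 250000 nM in this assay, at which 1 of the 3 values shown sits).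

Compound 4 `CCCNC(=O)CN1C(=O)/C(=C/c2ccc(-c3ccc(Cl)cc3)o2)SC1=S` differs from compound 3 in one place: propyl in place of 1H-tetrazol-5-yl on an amide-type nitrogen. For the measured compounds named here, three measured steps bear on this position on the amide-type nitrogen. From compound 1 to compound 2, an at least 3.6-fold lower number from compound 1 to compound 2 (0.56 log units; beyond the scatter); from compound 1 to compound 3, an at least 4.8-fold lower number from compound 1 to compound 3 (0.68 log units; beyond the scatter); and between the two compounds that carry a number, a 1.3-fold lower number from compound 2 to compound 3 (0.12 log units; within the scatter). Thus the 4-bromobenzyl and 1H-tetrazol-5-yl groups, unlike in ring count and in counted donors and acceptors, gave numbers within the scatter of each other, and only the 3-cyano-4-(trifluoromethyl)phenyl of compound 1 stood apart as a limit. A propyl chain, with no ring, is therefore expected to leave the number near that of compound 3, with a 1.3-fold higher number from compound 3 to compound 4 (0.10 log units; within the scatter). For compound 4 the estimate in this assay is 65000 nM, within a range from 20000 nM to 220000 nM.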

Compound 4, half-maximal inhibitory concentration: 50000 nM
For compound 4 the middle estimate is 1.3-fold (0.11 log units) above the measured one; low and high end bracket the measured number.
By their numbers in this assay, from the lowest: compounds 4, 3 and 2 (each within the scatter of the next). At a limit, above all of these: compound 1.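

In this assay, removing the ring from the group on this amide-type nitrogen left the number in place: propyl in place of 1H-tetrazol-5-yl gives a 1.0-fold lower number from compound 3 to compound 4 (0.02 log units; within the scatter), and ethyl in place of 4-bromophenyl on the saturated chain carbon gives a 1.4-fold lower number from compound 2 to compound 4 (0.13 log units; within the scatter). Among these compounds, then, neither a ring on this nitrogen nor the hydrogen-bond donor and acceptors counted on the 1H-tetrazol-5-yl group is needed to reach a number of this size. Only the 3-cyano-4-(trifluoromethyl)phenyl of compound 1 stays apart, with an at least 5.0-fold lower number from compound 1 to compound 4 (0.69 log units; beyond the scatter), and that step rests on a limit: the limit of > 250000 nM in this assay, at which 1 of the 4 values shown sits.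

On these data alone, whether an amine or a carboxylic acid at the end of the propyl chain, or a longer chain, would move the number beyond the scatter stays open. Also open, as far as these compounds go, is whether the nitrile or the trifluoromethyl sets compound 1 apart.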